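Cyclopropyl to isopropyl on the ring amide carbonyl

A few compounds are considered here, and "the series" means these few. Any claim that something is new, unique, unknown or untested is made for them only; others in the source may bear on it.

Measured so far:
- compound 1, `O=C(Nc1ccc(OC(F)(F)F)c(F)c1)NC1CCN(C(=O)C2CC2)CC1`: 4.19
- compound 2, `O=C(CC1CCN(C(=O)C2CC2)CC1)Nc1ccc(OC(F)(F)F)c(F)c1`: 5.11
- compound 3, `CC(C)C(=O)N1CCC(NC(=O)Nc2ccc(OC(F)(F)F)c(F)c2)CC1`: 4.73

All three numbers come from a physicochemical assay for lipophilicity, read by HPLC, with a stated time of 90 min, tested at 100 uM; a lower number here means a more polar compound, a higher number a more lipophilic compound. Compound 1 and compound 3 share a core and differ in one place: isopropyl in place of cyclopropyl on a carbonyl carbon. That step, a number 0.54 log units higher from compound 1 to compound 3 (beyond the scatter), lies beyond the scatter. Compound 2 stands highest of the three values; its nearest neighbour in value is compound 3, its furthest compound 1. The difference between the core of compound 2 and the core of compound 1 is not broken down here.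

Compound 4, `CC(C)C(=O)N1CCC(CC(=O)Nc2ccc(OC(F)(F)F)c(F)c2)CC1`, has not yet been measured. It is related to compound 2 by the same change that relates compound 3 to compound 1: isopropyl in place of cyclopropyl on a carbonyl carbon. The place lines of the two changes read the same word for word, so the change is counted as the same.

Within the data shown here, with only one measured instance of the change in hand, the expectation for compound 4 rests on the step seen from compound 1 to compound 3. Compound 4 is expected to sit above compound 2 by about a number 0.54 log units higher from compound 2 to compound 4 (beyond the scatter), a step of the same size as a number 0.54 log units higher from compound 1 to compound 3 (beyond the scatter). Compound 4 is therefore estimated at 5.65, with a range from 5.25 to 6.05, the range widened because the step is carried over from one pair only and the value of compound 2 is already the highest of the series.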

Compound 4, partition coefficient: 5.81
For compound 4 the middle estimate is 0.16 log units below the measured one; the measured number falls inside the stated range.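

In this assay the change from cyclopropyl to isopropyl on a carbonyl carbon gives a number 0.70 log units higher from compound 2 to compound 4 (beyond the scatter) on the core of compound 2 and a number 0.54 log units higher from compound 1 to compound 3 (beyond the scatter) on the core of compound 1; the two steps run in the same direction and each lies beyond the scatter. This shows that the change carries over between these two cores with its direction intact, but it rests on two pairs only and shows neither that the two steps are equal in size nor that the same direction would hold on any core outside this series. Nothing measured here accounts for the step on either core, and no explanation can be offered from these compounds.

The compounds shown leave open how a tert-butyl group, or a longer chain such as n-butyl, would read in place of isopropyl on the same carbonyl carbon, and so whether the steps seen here extend beyond this one pair of groups. They also leave open whether the change would keep its direction on a core that carries an amine or a carboxylic acid.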